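Methylamino in place of bromo on the fused ring

The source may hold more compounds than are shown below. What is called first, only, known or untested is meant among the compounds shown, and "the series" means these compounds.

Compound 1 `O=C(Nc1ccc(-n2ncc3c(C(F)(F)F)cccc32)cc1)Nc1ccc(Cl)c(C(F)(F)F)c1` sits at a limit in a functional assay on SGC-7901 cells (Homo sapiens) for cytotoxicity, read by MTT assay, with a stated time of 72 h (on this read-out lower numbers stand for stronger inhibition and higher numbers for weaker inhibition), namely > 32000 nM.
Compound 2 `O=C(Nc1ccc(-n2ncc3c(Br)cccc32)cc1)Nc1ccc(Cl)c(C(F)(F)F)c1` gives 16600 nM in this assay.
Compound 3 `Cc1cccc2c1cnn2-c1ccc(NC(=O)Nc2ccc(Cl)c(C(F)(F)F)c2)cc1` gives 14200 nM in this assay.

The three compounds share one core and differ only in the group on the fused ring. Compound 1 is known only through (the limit of > 32000 nM in this assay, at which 1 of the 3 values shown sits). Of the two numbers obtained, that of compound 2 cannot be told apart from that of compound 3: a 1.2-fold lower number from compound 2 to compound 3 (0.07 log units; within the scatter).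

Compound 4 `CNc1cccc2c1cnn2-c1ccc(NC(=O)Nc2ccc(Cl)c(C(F)(F)F)c2)cc1` arises from compound 2 by methylamino in place of bromo on an aromatic carbon. Two measured steps leave the trifluoromethyl of compound 1 for a smaller group and give numbers, an at least 1.9-fold lower number from compound 1 to compound 2 (0.28 log units; that floor lies within the scatter) and an at least 2.2-fold lower number from compound 1 to compound 3 (0.35 log units; beyond the scatter), while the swap of bromo for methyl stays within the scatter. For the measured compounds named here, none of the measured steps brings in a group with a hydrogen-bond donor and acceptor, so the guidance is thin. The expectation is a step no larger than the scatter, a 1.3-fold lower number from compound 2 to compound 4 (0.11 log units; within the scatter), with the direction uncertain. Compound 4 is therefore estimated at 13000 nM, within 4000 nM to 40000 nM.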

Compound 4, half-maximal inhibitory concentration: 6900 nM
Estimate against measurement, compound 4: 1.9-fold (0.28 log units) above, within the range that was stated.
By their numbers in this assay, from the lowest: compound 4; then compounds 3 and 2 (each within the scatter of the next). At a limit, above all of these: compound 1.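

In this assay, for the compounds shown here, methylamino is the first group at this position on the fused ring to stand apart from both bromo (a 2.4-fold lower number from compound 2 to compound 4 (0.38 log units; beyond the scatter)) and methyl (a 2.1-fold lower number from compound 3 to compound 4 (0.31 log units; beyond the scatter)), two groups whose own swap stayed within the scatter. So among the smaller groups, this position does respond to what is placed on it, and the group that produces the response is the one that brings a hydrogen-bond donor and acceptor. Compound 1 is known only through a limit, so the step from it is a floor (an at least 4.6-fold lower number from compound 1 to compound 4 (0.66 log units; beyond the scatter)), and the evidence on compound 1 is just this: the limit of > 32000 nM in this assay, at which 1 of the 4 values shown sits.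

As far as these compounds go, whether the change depends on the hydrogen on the nitrogen stays open; a plain amine, a dimethylamino group or a methoxy group at this position would bear on that. From the compounds shown here alone, it is also open whether a longer chain on that nitrogen would lower the number further.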